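Open-chain oxime ether in place of thiophene on the shared core

This account rests on a few compounds, and the source may have more. Where it says the series, first, only, none or still open, it means among the compounds named here.

In a functional assay for activation of Alpha-1D adrenergic receptor (Homo sapiens) (on this read-out higher numbers stand for an effect only at larger amounts of compound and lower numbers for an effect already at smaller amounts), compound 1 `c1csc(-c2ccccc2NCC2=NCCN2)c1` gives 18.2 nM. Among the compounds with values here, compound 1 stands as the only compound with a number in this assay; the one further value shown is a limit. Compound 2 `Cc1cc(-c2ccccc2NCC2=NCCN2)on1` returns only a limit of the assay, < 100000 nM. The step that the limit leaves unreadable from compound 1 to compound 2 therefore cannot be sized, since the limit of < 100000 nM in this assay, at which 1 of the 2 values shown sits, leaves it unreadable.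

Compound 3 `CC/C(=N/OC)c1ccccc1NCC1=NCCN1` is not yet measured. It differs from compound 1 by a group of 6 heavy atoms (4 carbon, 1 nitrogen, 1 oxygen; no ring) in place of a group of 5 heavy atoms (4 carbon, 1 sulfur; one five-membered aromatic ring with 1 hetero atom), on an aromatic carbon. Within the data shown here, no measured step covers a change of this kind: the only measured change at the same position of the shared core exchanges one five-membered aromatic ring for another, and its size is hidden by the limit of < 100000 nM in this assay, at which 1 of the 2 values shown sits. Among the measured compounds shown here, what can be said is that the one measured change at this position ended in a limit rather than a number. Given that, a loss beyond the scatter is expected for compound 3, of uncertain size, a 33-fold higher number from compound 1 to compound 3 (1.52 log units; beyond the scatter). Compound 3 is estimated at 600 nM in this assay, with a range from 40 nM to 20000 nM, and a real chance that only a limit is reported.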

Compound 3, half-maximal effective concentration: < 5020 nM
Compound 3: a limit, no number (the forecaster's own chance of this, stated with the estimate: 25%); the middle value does not contradict the limit.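

In this assay compound 3 gives < 5020 nM, which is a limit and not a number. Its steps from compound 1 and from compound 2 therefore cannot be read. The compounds shown leave open how large the change is when thiophen-2-yl on the shared core is replaced by either of the other two groups.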